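Amide for Sulfonylpyridine: Solubility Outlook for Compound 3

A few compounds are considered here, and "the series" means these few. Any claim that something is new, unique, unknown or untested is made for them only; others in the source may bear on it.

Compound 1 `CS(=O)(=O)c1cncc(-c2cnc3ccc(-c4cccc(S(=O)(=O)C5CC5)c4)nn23)c1` and compound 3 `NC(=O)c1ccc(-c2cnc3ccc(-c4cccc(S(=O)(=O)C5CC5)c4)nn23)cc1` share a core that carries a cyclopropylsulfonylphenyl group and differ only in the group on the other side. In a physicochemical assay for solubility, at pH 6.5 (on this read-out lower numbers stand for lower solubility and higher numbers for higher solubility), compound 1 gives < 5000 nM, which is a limit of the assay and not a number, so only its position at the low end of the measured values is known, as the limit of < 5000 nM in this assay, at which 1 of the 2 values shown sits, records. Compound 2 `CS(=O)(=O)c1cccc(-c2ccc3ncc(-c4ccc(S(=O)(=O)CCCN)cc4)n3n2)c1`, which carries a different pair of substituents, gives 180000 nM in this assay, a number well inside the measurable range.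

The change from compound 1 to compound 3 is 4-carbamoylphenyl in place of 5-(methylsulfonyl)pyridin-3-yl on an aromatic carbon. For the measured compounds named here, no measured pair of compounds shows what such an exchange does to solubility here, and compound 2 differs from both in more than one place, so it cannot serve as a guide. The expected step is a number no lower from compound 1 to compound 3 (the limit leaves the size open), not beyond the usual scatter. The estimate for compound 3 is 5000 nM, with a range from 1000 nM to 30000 nM, and a fair chance that this assay again reports only a limit.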

Compound 3, solubility: < 5000 nM
Compound 3 gave a limit, no number; the forecaster's own chance of this, stated with the estimate: 50%; the middle value lies on the limit itself.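

In this assay compound 3 gives < 5000 nM, a limit of the assay and not a number, as compound 1 does, so no step between compound 1 and compound 3 can be read: the limit of < 5000 nM in this assay, at which 2 of the 3 values shown sit.

The compounds shown leave open where the solubility of compound 1 and compound 3 actually lies, and so what 4-carbamoylphenyl in place of 5-(methylsulfonyl)pyridin-3-yl does to it.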